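A few compounds are considered here, and "the series" means these few. Any claim that something is new, unique, unknown or untested is made for them only; others in the source may bear on it.

Working notes on the series.

Compound 3 `COc1ccc(C(=O)O)cc1OCCCCOc1ccc(C(=O)C(C)C)c(O)c1C` is the reference point of the set so far. In an assay on HEK293 cells for positive allosteric modulation of metabotropic glutamate receptor 3 (Rattus norvegicus), read by thallium flux, with a stated time of 2.5 min (a higher number here means that more compound is needed for the effect, a lower number that less compound is needed), compound 3 gives 588 nM. Compound 2 `CCC(=O)c1ccc(OCCCCOc2cc(C(=O)O)ccc2OC)c(C)c1O` differs from it by one change, (hydrogen in place of methyl on a saturated chain carbon bound to a carbonyl carbon and a saturated chain carbon), and in this assay compound 2 gives 6360 nM; the step of an 11-fold higher number from compound 3 to compound 2 (1.03 log units; beyond the scatter) is the only one in the set where a single change can be read off directly. Compound 1 `Cc1cc(C(=O)O)ccc1OCCCCOc1ccc(C(=O)CC(C)C)c(O)c1C` sits between the two: in this assay compound 1 gives 1850 nM, a higher number than compound 3 and a lower one than compound 2. The difference between the core of compound 1 and the core of compound 3 is not broken down here.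

Compound 4 `CCCC(=O)c1ccc(OCCCCOc2ccc(C(=O)O)cc2C)c(C)c1O` has not yet been measured. It differs from compound 1 by hydrogen in place of methyl on a saturated chain carbon bound to two saturated chain carbons. Within the data shown here, this is the same kind of change as the one from compound 3 to compound 2, not the same change: there the methyl leaves a saturated chain carbon bound to a carbonyl carbon and a saturated chain carbon, here it leaves a saturated chain carbon bound to two saturated chain carbons, one bond further from the carbonyl. The expectation for compound 4 is a higher number than compound 1, resting on the step of an 11-fold higher number from compound 3 to compound 2 (1.03 log units; beyond the scatter), but a smaller one, since the change sits further out; the estimated step is a 3.2-fold higher number from compound 1 to compound 4 (0.51 log units; beyond the scatter). For compound 4 in this assay the estimate is 6000 nM, with a range from 2500 nM to 15000 nM.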

Compound 4, half-maximal effective concentration: > 10000 nM
Compound 4: no number, only a limit; the forecaster's own chance of this, stated with the estimate: 15%; middle value at least 1.6-fold (0.22 log units) away from the limit.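

In this assay compound 4 gives > 10000 nM, which is a limit of the assay and not a number. Hydrogen in place of methyl raises the number on the core of compound 1, an at least 5.4-fold higher number from compound 1 to compound 4 (0.73 log units; beyond the scatter), and this is the same direction as on the other core, an 11-fold higher number from compound 3 to compound 2 (1.03 log units; beyond the scatter), so within these two pairs the direction of the change carries from one core to the other. This does not show that the size carries over, and two pairs are no basis for a rule across the series: the same change on two cores in this assay, an 11-fold higher number (1.03 log units; beyond the scatter) from compound 3 to compound 2 and an at least 5.4-fold higher number (0.73 log units; beyond the scatter) from compound 1 to compound 4; the limit leaves it open whether they differ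

The compounds shown contain no pair with the same chain on both cores, so the contribution of the core cannot be separated from that of the chain. Also open, on these data alone, is how a longer chain than isobutylcarbonyl, or a cyclopropyl group in its place, would read on either core.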